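Aromatic-nitrogen substituent change from compound 3 to compound 4

The source may hold more compounds than are shown below. What is called first, only, known or untested is meant among the compounds shown, and "the series" means these compounds.

Measured compounds so far, all in an assay on isolated protein for inhibition of DNA nucleotidylexotransferase (Homo sapiens), read by scintillation counting, with a stated time of 10 min; a higher number here means a weaker inhibitor, a lower number a stronger inhibitor:

- Compound 1 `CCOC(=O)C(=O)CC(=O)/C=C/c1cn(CCC(C)C)c2ccccc12`; compound 1 gives > 40 uM, which is a limit of the assay, not a number.
- Compound 2 `C=C(C)Cn1cc(/C=C/C(=O)CC(=O)C(=O)OCC)c2ccccc21`; compound 2 gives > 40 uM, again a limit of the assay.
- Compound 3 `CCOC(=O)C(=O)CC(=O)/C=C/c1cn(-c2ccc(O)cc2)c2ccccc12`; compound 3 gives > 40 uM, also a limit of the assay.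

Every value in this assay therefore sits at the same limit (the limit of > 40 uM in this assay, at which 3 of the 3 values shown sit), and compound 3 stands there with no number of its own. The three steps between the measured compounds are all left unreadable by their limits: a step that the two limits leave unreadable from compound 1 to compound 2, a step that the two limits leave unreadable from compound 1 to compound 3 and a step that the two limits leave unreadable from compound 2 to compound 3. None of them tells how large a change on the aromatic nitrogen can be.

Compound 4 `CCOC(=O)C(=O)CC(=O)/C=C/c1cn(Cc2ccc(F)cc2)c2ccccc12` is the next member. The change is 4-fluorobenzyl in place of 4-hydroxyphenyl on an aromatic nitrogen. For the measured compounds named here, no measured step bears readably on it, since each neighbouring change on the aromatic nitrogen left the value at the limit. The expectation is therefore of no step beyond the scatter, and most likely of another limit rather than a number.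

Compound 4 is expected to give about 40 uM in this assay, within 20 uM to 100 uM. The step this estimate implies, a number no higher from compound 3 to compound 4 (the limit leaves the size open), is expected to be none beyond the scatter.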

Compound 4, concentration for 50% inhibition: > 40 uM
Compound 4: only a limit was reported; the forecaster's own chance of this, stated with the estimate: 80%; the middle value lies on the limit itself.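

In this assay compound 4 gives > 40 uM, a limit of the assay and not a number. No new step can be read from compound 4 to compound 1, compound 2 or compound 3, as all four compounds share one limit: the limit of > 40 uM in this assay, at which 4 of the 4 values shown sit.

The compounds shown leave open whether any substituent on the aromatic nitrogen of the shared core gives a measurable value in this assay.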